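This account rests on a few compounds, and the source may have more. Where it says the series, first, only, none or still open, it means among the compounds named here.

Measured in a functional assay on the whole organism with Rattus norvegicus as the target; on this read-out higher numbers stand for an effect only at larger amounts of compound and lower numbers for an effect already at smaller amounts:
- compound 1 `CCOCCOC(=O)C(=O)Nc1nc(-c2cc(Cl)no2)cs1`: 6 mg/kg
- compound 2 `CCOCCOC(=O)C(=O)Nc1nc(-c2cc(Br)no2)cs1`: 11 mg/kg
- compound 3 `CCOCCOC(=O)C(=O)Nc1nc(-c2cc(Br)no2)c(CC)s1`: 3 mg/kg

Compound 2, at 11 mg/kg, forms the upper end of these numbers together with compound 1, and the two lie within the scatter of each other. Compound 3 stands clearly apart, with a 3.7-fold lower number from compound 2 to compound 3 (0.56 log units; beyond the scatter).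

The next compound is compound 4 `CCOCCOC(=O)C(=O)Nc1nc(-c2cc(OC)no2)cs1`, which has methoxy in place of bromo on an aromatic carbon. The group sits on a five-membered aromatic ring with 1 nitrogen and 1 oxygen, next to the ring nitrogen.

For the measured compounds named here, the closest evidence is the one exchange measured at this same place: a 1.8-fold higher number from compound 1 to compound 2 (0.26 log units; within the scatter), bromo in place of chloro. That step stayed within the scatter. The ethyl step, a 3.7-fold lower number from compound 2 to compound 3 (0.56 log units; beyond the scatter), is modest and lies at another place on the shared core, so it bears little on this change. Going by the values given here, no methoxy compound has been measured yet, so the expectation remains loose, and no step beyond the scatter is expected in this assay.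

The expected step is a 1.4-fold lower number from compound 2 to compound 4 (0.14 log units; within the scatter). For compound 4 the estimated value is 8 mg/kg, with an expected range of 3 mg/kg to 22 mg/kg.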

Compound 4, dose for half-maximal effect: 3 mg/kg
Beside the measured number, compound 4's estimate is 2.7-fold (0.43 log units) above it; the range from low to high includes it.
By their numbers in this assay, from the lowest: compounds 3, 4, 1 and 2 (each within the scatter of the next, the first and the last beyond it).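

In this assay, for the compounds shown here, the aromatic carbon next to the ring nitrogen can carry a step beyond the scatter: methoxy in place of bromo gives (a 3.7-fold lower number from compound 2 to compound 4 (0.56 log units; beyond the scatter)), whereas the only earlier exchange at this place, between the two halogens, stayed within it. Read against chloro, the same replacement gives (a 2.0-fold lower number from compound 1 to compound 4 (0.30 log units; within the scatter)), which leaves compound 4 and compound 1 unseparated, so the step beyond the scatter holds only when bromo in compound 2 is the reference. No supporting data bear on the reason for this difference between the two exchanges.

Still open is whether the result belongs to methoxy alone or extends to ethoxy, an amine or a longer ether chain at this same carbon, as the compounds shown hold only chloro, bromo and methoxy there. Also open, as far as these compounds go, is whether ethyl at the other place on the shared core, which gave a step beyond the scatter with bromo present, would do the same with methoxy present.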